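Adding a third methoxy group to compound 2

A few compounds are considered here, and "the series" means these few. Any claim that something is new, unique, unknown or untested is made for them only; others in the source may bear on it.

Measured so far:
compound 1 `Nc1cc(N)c2nc(-c3ccccc3)c(NCc3ccc(Cl)c(Cl)c3)nc2c1` gives 15800 nM
compound 2 `COc1ccc(CNc2nc3cc(N)cc(N)c3nc2-c2ccccc2)cc1OC` gives 26900 nM
compound 3 `CCOC(=O)[C@H](CCC(=O)O)NC(=O)c1ccc(Sc2nc3cc(N)cc(N)c3nc2-c2ccccc2)cc1` gives 40700 nM

All three compounds share the same core and were tested in a functional assay on UACC-257 cells (Homo sapiens) for inhibition, read by sulforhodamine B assay, with a stated time of 48 h; on this read-out higher numbers stand for weaker inhibition of growth and lower numbers for stronger inhibition of growth. Compound 2 sits in the middle of the three numbers: compound 3 lies on one side and compound 1 on the other, and both gaps are within the usual scatter of repeated measurements, so the three compounds cannot be told apart on these data.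

For the measured compounds named here, compound 4 `COc1cc(CNc2nc3cc(N)cc(N)c3nc2-c2ccccc2)cc(OC)c1OC` is the one change from compound 2: methoxy in place of hydrogen on an aromatic carbon. The new methoxy sits on the same six-membered ring that already carries two methoxy groups, ortho to one of them.

Going by the values given here, only one measured step involves this ring, the step of a 1.7-fold higher number from compound 1 to compound 2 (0.23 log units; within the scatter), which exchanges the whole dichloro-substituted ring for the dimethoxy-substituted ring and still stays within the scatter. A single added methoxy is a smaller change than that, so no step beyond the scatter is expected; compound 4 is estimated at 27000 nM (from 12000 nM to 60000 nM), which means an expected step of a 1.0-fold higher number from compound 2 to compound 4 (0.00 log units; within the scatter).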

Compound 4, concentration for total growth inhibition: 10700 nM
Compound 4: middle estimate off by 2.5-fold (0.40 log units), on the high side; measured number below the stated range.
By their numbers in this assay, from the lowest: compounds 4, 1, 2 and 3 (each within the scatter of the next, the first and the last beyond it).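

In this assay the added methoxy gives a 2.5-fold lower number from compound 2 to compound 4 (0.40 log units; beyond the scatter) and this is the first step among these compounds to lie beyond the scatter. The earlier step on this ring swapped both ring substituents and could not be told from noise, whereas here a single methoxy in place of hydrogen, ortho to a methoxy group, gives a real though modest move towards stronger inhibition of growth. So this aromatic carbon is not indifferent to what it carries, even though the change adds only 2 heavy atoms. Nothing in hand gives a measured reason for the step.

This remains one step between one pair of compounds, so it shows nothing yet about whether the same methoxy would act in the same way on a different compound. It also leaves open whether the methoxy itself matters or whether another group on this carbon would do as well, such as a hydroxyl, a fluorine, an amine or a longer chain like ethoxy.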